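Compound 3 and the limit of the cytotoxicity assay

This account rests on a few compounds, and the source may have more. Where it says the series, first, only, none or still open, it means among the compounds named here.

Compound 1 `O=C(/C=C/CCCCCCc1ccccc1)N1CCCCCC1`: > 100000 nM (a limit)
Compound 2 `O=C(CCCCCCCCCCc1ccccc1)N1CCCCC1`: > 100000 nM (a limit)

Both compounds were tested in a functional assay on PANC-1 cells (Homo sapiens) for cytotoxicity, read by WST assay, with a stated time of 24 h; a lower number here means a stronger inhibitor, a higher number a weaker inhibitor. In this assay compound 1 gives > 100000 nM, which is a limit and not a number. Compound 2 gives > 100000 nM, again only a limit. The record so far is thus (the limit of > 100000 nM in this assay, at which 2 of the 2 values shown sit).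

Compound 3 `O=C(CCCCCCCCc1cccc(F)c1)N1CCCCC1` departs from compound 2 with 3-fluorophenyl in place of phenethyl on a saturated chain carbon, eight bonds along the chain from a carbonyl carbon.

For the measured compounds named here, no measured step gives a size for such a change. In this assay the expected change is none beyond the scatter, and a further limit is the likeliest report. The estimated change is a number no higher from compound 2 to compound 3 (the limit leaves the size open). For compound 3 the estimated value is 100000 nM, with an expected range from 40000 nM to 200000 nM.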

Compound 3, half-maximal inhibitory concentration: > 100000 nM
Compound 3: a limit, no number (the forecaster's own chance of this, stated with the estimate: 75%); the middle value sits exactly at the limit.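

In this assay compound 3 gives > 100000 nM, a limit and not a number. Compound 2 also has only a limit, so no step can be read between compound 2 and compound 3. The compounds shown leave open what number, if any, each would reach in this assay.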